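From a Chlorobenzyl Glycolate Ester to a Methyl(propyl) Glycolamide

This account rests on a few compounds, and the source may have more. Where it says the series, first, only, none or still open, it means among the compounds named here.

Compound 1 `CCCOC(=O)/C=C/c1ccc(NC(=O)C2(NC(=O)c3ccc4c(C5CCCC5)c(-c5ncc(Cl)cn5)n(C)c4c3)CCC2)cc1OCC`: 0.35 h
Compound 2 `CCOc1cc(NC(=O)C2(NC(=O)c3ccc4c(C5CCCC5)c(-c5ncc(Cl)cn5)n(C)c4c3)CCC2)ccc1/C=C/C(=O)OCC(=O)OCc1ccc(Cl)cc1`: 11.4 h

Within the data shown here, in an ADME assay (liver) for pharmacokinetics, with Liver microsome (Rattus norvegicus) as the target, using microsomes (on this read-out higher numbers stand for a longer-lived compound and lower numbers for a shorter-lived compound), compound 2 gives the highest of the two numbers, and the only measured step, a 33-fold higher number from compound 1 to compound 2 (1.51 log units; beyond the scatter), is large. Compound 3 `CCCN(C)C(=O)COC(=O)/C=C/c1ccc(NC(=O)C2(NC(=O)c3ccc4c(C5CCCC5)c(-c5ncc(Cl)cn5)n(C)c4c3)CCC2)cc1OCC` differs from compound 2 by methyl(propyl)amino in place of (4-chlorobenzyl)oxy on a carbonyl carbon. Among the measured compounds shown here, that single measured step bears on it, since it changed the same chain, and it shows that the number moves strongly when this chain is altered; no measured pair shows this particular exchange. Compound 3 is therefore expected, with wide uncertainty, to give 4 h, ranging from 0.7 h to 20 h. The step of a 2.9-fold lower number from compound 2 to compound 3 (0.45 log units; beyond the scatter) is the expected outcome.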

Compound 3, half-life: 0.317 h
For compound 3 the middle estimate is 13-fold (1.10 log units) above the measured one; measured number outside the range, below it.
By their numbers in this assay, from the lowest: compounds 3 and 1 (each within the scatter of the next); then compound 2.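

In this assay, the step of a 36-fold lower number from compound 2 to compound 3 (1.56 log units; beyond the scatter) shows that the long half-life of compound 2 does not survive in the same chain once methyl(propyl)amino replaces (4-chlorobenzyl)oxy on a carbonyl carbon. The step of a 1.1-fold lower number from compound 1 to compound 3 (0.04 log units; within the scatter) stays within the scatter, so the methyl(propyl)carbamoyl chain gives no gain over the ethyl chain of compound 1. Nothing available gives a reason for this difference. The compounds shown leave open whether the ring or the ester link of the (4-chlorobenzyl)oxy group carries the effect. An amide bearing the same 4-chlorobenzyl group would separate the two.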